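The source may hold more compounds than are shown below. What is called first, only, known or untested is meant among the compounds shown, and "the series" means these compounds.

Measured compounds in a functional assay on DLD-1 cells (Homo sapiens) for inhibition, read by MTT assay, with a stated time of 72 h; a lower number here means a stronger inhibitor, a higher number a weaker inhibitor:
compound 1 `COc1ccc(CCCNCc2c(OC)cc(Oc3ccc(Nc4ccccc4)cc3)cc2OC)cc1`: 4650 nM
compound 2 `COc1cc(Oc2cccc(Nc3ccccc3)c2)cc(OC)c1CNCCNC(C)=O`: 6010 nM
compound 3 `COc1cc(Oc2cccc(Nc3ccccc3)c2)cc(OC)c1CCO`: 18100 nM

Compound 2 stands second highest of the three numbers; its value and that of compound 1 lie within the scatter of one another, while compound 3 is set apart by a 3.0-fold higher number from compound 2 to compound 3 (0.48 log units; beyond the scatter). Compound 4 `COc1cc(Oc2cccc(Nc3ccccc3)c2)cc(OC)c1CNCc1ccc(O)cc1` carries the change (4-hydroxyphenyl in place of acetamidomethyl on a saturated chain carbon bound to an amine nitrogen). Going by the values given here, no measured step covers this exact exchange; the one step on the same chain, a 3.0-fold higher number from compound 2 to compound 3 (0.48 log units; beyond the scatter), removed the amine altogether and went upward. Compound 1, which also keeps a secondary amine, gives 4650 nM, close to compound 2. The expectation for compound 4 in this assay is therefore a step of about a 1.5-fold lower number from compound 2 to compound 4 (0.18 log units; within the scatter), not beyond the scatter. Compound 4 is estimated at 4000 nM, range 1500 nM to 11000 nM.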

Compound 4, half-maximal inhibitory concentration: 2690 nM
For compound 4 the middle estimate is 1.5-fold (0.17 log units) above the measured one; measured number inside the range.
By their numbers in this assay, from the lowest: compounds 4, 1 and 2 (each within the scatter of the next, the first and the last beyond it); then compound 3.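

At the saturated chain carbon bound to an amine nitrogen, 4-hydroxyphenyl in place of acetamidomethyl gives, in this assay, a 2.2-fold lower number from compound 2 to compound 4 (0.35 log units; beyond the scatter), the first step shown at this place that runs downward. The larger exchange, (4-hydroxybenzyl)amino in place of hydroxymethyl, gives a 6.7-fold lower number from compound 3 to compound 4 (0.83 log units; beyond the scatter), so an aromatic ring on this amine is compatible with a lower number in this series. Nothing available explains either step.

Open, from the compounds shown here alone, is whether the hydroxyl itself counts, which a plain benzyl or a 4-methoxybenzyl on the amine of the shared core would test. Also open, going by these compounds, is what a phenethyl group would give there.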